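The source may hold more compounds than are shown below. What is called first, only, known or untested is meant among the compounds shown, and "the series" means these compounds.

Two members of the series carry numbers in an assay on mitochondria (strain BALB/c) for inhibition of glycerol-3-phosphate acyltransferase 1, mitochondrial (Mus musculus), read by scintillation counting, with a stated time of 10 min; a lower number here means a stronger inhibitor, a higher number a weaker inhibitor. Compound 1 `CCCCCCCCS(=O)(=O)Nc1cc(-c2cccc(F)c2)ccc1C(=O)O` gives 32600 nM there, and compound 2 `CCCCCCCCS(=O)(=O)Nc1ccc(-c2ccc(CCCC)cc2)cc1C(=O)O` gives 9000 nM, the lower of the two, with compound 1 standing a gap beyond the scatter above it. Compound 3 `CCCCCCCCS(=O)(=O)Nc1ccc(-c2ccc(O)cc2)cc1C(=O)O` has not been measured; relative to compound 2 it carries hydroxy in place of butyl on an aromatic carbon. For the measured compounds named here, no single-change step has been measured in this assay, so the size of this step is uncertain; a move toward a higher number, past the scatter, is expected as a 3.3-fold higher number from compound 2 to compound 3 (0.52 log units; beyond the scatter). For compound 3 the estimate is 30000 nM, within 10000 nM to 100000 nM.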

Compound 3, half-maximal inhibitory concentration: 47300 nM
Compound 3: middle estimate off by 1.6-fold (0.20 log units), on the low side, and the stated range covers the measured number.
By their numbers in this assay, from the lowest: compound 2; then compounds 1 and 3 (each within the scatter of the next).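

Hydroxy in place of butyl on an aromatic carbon gives the only single-place step in the series so far (a 5.3-fold higher number from compound 2 to compound 3 (0.72 log units; beyond the scatter)), a modest one. This position para to a large group is therefore not indifferent to what it carries, and of these two groups butyl gives the lower number. Nothing at hand accounts for the step.

Open, on these data alone, is whether the number follows the butyl chain's length or the hydroxy itself. A methyl, a methoxy or a hexyl chain at this place would separate the two.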